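The source may report more compounds than this note shows. Statements on the series, on what has been measured and on what is new or still open speak of the compounds shown alone.

In a functional assay on HeLa cells (Homo sapiens) for antiproliferative activity, read by MTT assay, with a stated time of 72 h (on this read-out higher numbers stand for weaker inhibition and lower numbers for stronger inhibition), compound 1 `COc1ncc(-c2ccc3c(c2)N(c2ccc(C)cc2)C(=O)CO3)cc1NS(=O)(=O)c1ccc(F)cc1` gives 4650 nM. Among the numbers shown, compound 1 stands lowest, with compound 2 `O=C1COc2ccc(-c3cccc(NS(=O)(=O)c4ccc(F)cc4)c3)cc2N1c1ccccc1` nearest at 17700 nM, a gap that lies beyond the usual scatter of this assay. Compound 3 `O=C1COc2ccc(-c3ccc(O)cc3)cc2N1` is reported in this assay only as a limit, > 40000 nM. The three values thus include (the limit of > 40000 nM in this assay, at which 1 of the 3 values shown sits).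

Compound 4 `COc1ncc(-c2ccc3c(c2)N(C2CCCCC2)C(=O)CO3)cc1NS(=O)(=O)c1ccc(F)cc1` has not yet been measured in this assay. It differs from compound 1 in one place: cyclohexyl in place of 4-methylphenyl on an amide-type nitrogen in a ring. Going by the values given here, no pair of measured compounds here differs in only one place, so this exchange of an aromatic ring for a non-aromatic ring of carbon on the amide-type nitrogen in a ring has no measured counterpart among the three compounds.

A modest weakening is expected in this assay for compound 4 a 1.7-fold higher number from compound 1 to compound 4 (0.24 log units; within the scatter), while a result within the scatter of the starting point remains plausible. Compound 4 is therefore estimated at 8000 nM in this assay, in a range from 2500 nM to 30000 nM.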

Compound 4, half-maximal inhibitory concentration: 6100 nM
Compound 4: the middle estimate sits 1.3-fold (0.12 log units) above what was measured, within the range that was stated.
By their numbers in this assay, from the lowest: compounds 1 and 4 (each within the scatter of the next); then compound 2. At a limit, above all of these: compound 3.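

In this assay, the exchange of 4-methylphenyl for cyclohexyl on the amide-type nitrogen gives a 1.3-fold higher number from compound 1 to compound 4 (0.12 log units; within the scatter), the only step at this position among the compounds shown. For this pair, a six-membered non-aromatic ring of carbon therefore takes the place of a six-membered aromatic ring of carbon without a change that stands clear of the scatter, so an aromatic ring at this place is not needed to keep the value of compound 1. Nothing given here bears on why the two groups read alike.

Going by these compounds, it stays open how this nitrogen would respond to a group of another kind, such as a longer chain like n-hexyl, or a cyclohexyl ring carrying an amine or a carboxylic acid. On these data alone, whether a smaller group such as methyl would keep the value is also open.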